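Swapping a methyl for a 4-methylpiperazin-1-yl group

The source may report more compounds than this note shows. Statements on the series, on what has been measured and on what is new or still open speak of the compounds shown alone.

compound 1 `Cc1ccc(NC(=O)C2CCN(C/C=C/c3ccccc3)CC2)cc1`: 29600 nM
compound 2 `CCCCCc1ccc(NC(=O)C2CCN(C/C=C/c3ccccc3)CC2)cc1`: 3880 nM
compound 3 `O=C(Nc1cccc(C(F)(F)F)c1)C1CCN(C/C=C/c2ccccc2)CC1`: 15600 nM

In a functional assay on A549 cells (Homo sapiens) for inhibition, read by MTT assay, with a stated time of 72 h (a higher number here means a weaker inhibitor, a lower number a stronger inhibitor), compound 1 gives 29600 nM and compound 3 gives 15600 nM, two values within the usual scatter of each other. One measured step stands out: a 7.6-fold lower number from compound 1 to compound 2 (0.88 log units; beyond the scatter). That change is butyl in place of hydrogen on a saturated chain carbon bound to an aromatic carbon, so it acts on the methyl group of compound 1.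

Compound 4 `CN1CCN(c2ccc(NC(=O)C3CCN(C/C=C/c4ccccc4)CC3)cc2)CC1` alters that same methyl group: 4-methylpiperazin-1-yl in place of methyl on an aromatic carbon. In short, this is 4-methylpiperazin-1-yl in place of methyl on an aromatic carbon, para to a large group. Among the measured compounds shown here, the butyl step is the only measured guide, and it shows a larger group going with a lower number. For the measured compounds named here, no measured compound yet carries a ring at this place, so the guide is loose. A lower number is expected, though a smaller drop than in the butyl step, and the estimated change is a 3.0-fold lower number from compound 1 to compound 4 (0.47 log units; beyond the scatter). For compound 4 the expected value is 10000 nM, with an estimated range from 2500 nM to 30000 nM.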

Compound 4, half-maximal inhibitory concentration: 19900 nM
Compound 4: middle estimate off by 2.0-fold (0.30 log units), on the low side; the measured number falls inside the stated range.
By their numbers in this assay, from the lowest: compound 2; then compounds 3, 4 and 1 (each within the scatter of the next).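

In this assay, putting 4-methylpiperazin-1-yl in place of methyl on this aromatic carbon gives a 1.5-fold lower number from compound 1 to compound 4 (0.17 log units; within the scatter), so these two groups cannot be told apart here. A larger group at this place therefore does not by itself go with a lower number, and compound 4 goes against the lead suggested by the butyl step: the change from the pentyl chain to the ring gives a 5.1-fold higher number from compound 2 to compound 4 (0.71 log units; beyond the scatter). Nothing available here explains why the pentyl chain and the 4-methylpiperazin-1-yl group part ways.

From the compounds shown here alone, what remains open is whether the lower number of compound 2 depends on an unbroken carbon chain at this place. A hexyl chain would extend the comparison, while a pentyl chain ending in an amine would show whether adding nitrogen to the chain alone changes the number.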